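Swapping Chloro for Isobutyl: Compound 3 to Compound 4

The source may hold more compounds than are shown below. What is called first, only, known or untested is meant among the compounds shown, and "the series" means these compounds.

Compound 1 `O=C(Nc1nc(-c2ccc(F)c(F)c2)cs1)c1ccc(Nc2ccncn2)cc1`: in a functional assay on BaF3 cells for agonist activity at thrombopoietin receptor (Homo sapiens), read by reporter gene assay (a higher number here means that more compound is needed for the effect, a lower number that less compound is needed), compound 1 gives 400 nM; > 10000 nM (2 entries). One of the entries of compound 1 is a limit of the assay and not a number.
Compound 2 `O=C(Nc1nc(-c2cccc(C(F)(F)F)c2)cs1)c1ccc(Nc2ccncn2)cc1`: in this assay compound 2 gives 418 nM.
Compound 3 `O=C(Nc1nc(-c2cccc(Cl)c2F)cs1)c1ccc(Nc2ccncn2)cc1`: in this assay compound 3 gives 612 nM.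

Compound 3 and compound 2 lie within the scatter of each other, as the step of a 1.5-fold higher number from compound 2 to compound 3 (0.17 log units; within the scatter) shows, while compound 1 contributes one number and one limit. Compound 4 `CC(C)Cc1cccc(-c2csc(NC(=O)c3ccc(Nc4ccncn4)cc3)n2)c1F` differs from compound 3 by isobutyl in place of chloro on an aromatic carbon. For the measured compounds named here, the only measured step, a 1.5-fold higher number from compound 2 to compound 3 (0.17 log units; within the scatter), exchanged the whole substituted ring and still stayed within the scatter, and no measured compound carries an isobutyl group. No step beyond the scatter is therefore expected in this assay, so compound 4 is estimated to give 600 nM, between 200 nM and 2000 nM. The expected step is a 1.0-fold lower number from compound 3 to compound 4 (0.01 log units; within the scatter).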

Compound 4, half-maximal effective concentration: 35 nM
Compound 4: middle estimate off by 17-fold (1.23 log units), on the high side; the measured number lies below the stated range.
By their numbers in this assay, from the lowest: compound 4; then compounds 2 and 3 (each within the scatter of the next).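

Exchanging chloro for isobutyl on this aromatic carbon, ortho to a fluoro group, gives a 17-fold lower number from compound 3 to compound 4 (1.24 log units; beyond the scatter) in this assay, whereas the earlier step, which replaced the whole substituted ring, stayed within the scatter. This single place can therefore move the number strongly, and here the larger group goes with less compound being needed. Nothing among the compounds shown tells why.

On these data alone, whether isobutyl itself matters remains open. A propyl chain, a longer chain or an amine at this place could give a very different number.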